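Dioxolane series: alkyl extension at the amine-bearing carbon

A few compounds are considered here, and "the series" means these few. Any claim that something is new, unique, unknown or untested is made for them only; others in the source may bear on it.

Measured so far:
compound 1 `CN1CCCC[C@H]1[C@H]1COC(c2ccccc2)(c2ccccc2)O1` – 4400 nM
compound 2 `CCCN1CCCC[C@H]1[C@H]1COC(c2ccccc2)(c2ccccc2)O1` – 6800 nM
compound 3 `C[C@H](N)[C@H]1COC(c2ccccc2)(c2ccccc2)O1` – 607 nM

All three were run in a functional assay (brain) for displacement of a labelled ligand, with Rattus norvegicus as the target; a higher number here means a weaker inhibitor, a lower number a stronger inhibitor. Compound 3 gives the lowest number of the three; the step of a 7.2-fold lower number from compound 1 to compound 3 (0.86 log units; beyond the scatter) rests on the change (1-aminoethyl in place of 1-methylpiperidin-2-yl on a saturated ring carbon). Compound 1 and compound 2 are linked by ethyl in place of hydrogen on a saturated chain carbon bound to an amine nitrogen in a ring, which made the step of a 1.5-fold higher number from compound 1 to compound 2 (0.19 log units; within the scatter).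

Compound 4 `CCC[C@H](N)[C@H]1COC(c2ccccc2)(c2ccccc2)O1` is not yet measured. It differs from compound 3 by ethyl in place of hydrogen on a saturated chain carbon, two bonds along the chain from an amine nitrogen and a saturated ring carbon. This is the same kind of change as between compound 1 and compound 2, but the place differs: in compound 2 the ethyl sits on a saturated chain carbon bound to an amine nitrogen in a ring, in compound 4 on a saturated chain carbon two bonds along the chain from an amine nitrogen and a saturated ring carbon, and the two cores differ as counted above. Because the step of a 1.5-fold higher number from compound 1 to compound 2 (0.19 log units; within the scatter) stayed within the scatter, a step of similar size, a 1.3-fold higher number from compound 3 to compound 4 (0.12 log units; within the scatter), is expected for compound 4. Compound 4 is estimated at 800 nM in this assay, between 300 nM and 2500 nM.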

Compound 4, inhibition constant: 3450 nM
Estimate against measurement, compound 4: 4.3-fold (0.63 log units) below; the measured number lies above the stated range.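

The ethyl-for-hydrogen change does not carry over at a constant size between these cores in this assay: the same change on two cores in this assay, a 1.5-fold higher number (0.19 log units; within the scatter) from compound 1 to compound 2 and a 5.7-fold higher number (0.75 log units; beyond the scatter) from compound 3 to compound 4, 3.7-fold (0.57 log units) apart, beyond the scatter of two such steps

On the core of compound 3, the step is a 5.7-fold higher number from compound 3 to compound 4 (0.75 log units; beyond the scatter), while 1-aminobutyl in place of 1-methylpiperidin-2-yl gives a 1.3-fold lower number from compound 1 to compound 4 (0.11 log units; within the scatter), so the scatter does not separate compound 4 from compound 1. These two pairs differ in the place of the ethyl as well as in the core, so they do not show which of the two sets the gap, why it arises, or how the change would behave on another core.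

As far as these compounds go, it remains open how 1-aminopropyl, a longer chain or a branched chain would read in this place. An N-methyl amine on the 1-aminobutyl group is also an open case.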